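A Ring Replaces the Charged End of Compound 2

A few compounds are considered here, and "the series" means these few. Any claim that something is new, unique, unknown or untested is made for them only; others in the source may bear on it.

Among the measured compounds shown here, in a functional assay on CCRF-CEM cells (Homo sapiens) for cytotoxicity, read by MTT assay, with a stated time of 72 h (a higher number here means a weaker inhibitor, a lower number a stronger inhibitor), compound 2 `CCCCCCCCCCCCCCCCOP(=O)([O-])OCCC[N+](C)(C)C` gives 6200 nM, the lower of the two numbers measured so far. Compound 1 `CCCCCCCCCCCCCCCCOP(=O)([O-])OCCC[N+](C)(C)Cc1ccccc1` gives 62200 nM, so compound 2 is the stronger inhibitor of this pair. Compound 3 `CCCCCCCCCCCCCCCCOP(=O)([O-])OCCC[n+]1ccccc1` has not yet been measured. It differs from compound 2 at one place: a group of 6 heavy atoms (5 carbon, 1 nitrogen; one six-membered aromatic ring with 1 hetero atom) in place of a group of 4 heavy atoms (3 carbon, 1 nitrogen; no ring), on a saturated chain carbon, three bonds along the chain from an oxygen. The new group holds one six-membered aromatic ring with 1 hetero atom, and it sits on a saturated chain carbon, three bonds along the chain from an oxygen. Both the leaving and the entering group have a net charge of +1.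

For the measured compounds named here, only one measured step offers guidance: a 10-fold lower number from compound 1 to compound 2 (1.00 log units; beyond the scatter). There, hydrogen took the place of phenyl on a saturated chain carbon bound to an amine nitrogen. That is a different change, and a single one, so it suggests a direction more than a size. Since the ring-bearing compound 1 gives 62200 nM, a modest rise, smaller than that step, is expected here. The expected step is a 2.1-fold higher number from compound 2 to compound 3 (0.32 log units; beyond the scatter). For compound 3 the estimated value is 13000 nM, with an expected range from 4500 nM to 40000 nM.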

Compound 3, half-maximal inhibitory concentration: 34600 nM
Compound 3: the middle estimate sits 2.7-fold (0.43 log units) below what was measured; the measured number falls inside the stated range.
By their numbers in this assay, from the lowest: compound 2; then compounds 3 and 1 (each within the scatter of the next).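

In this assay, the step of a 5.6-fold higher number from compound 2 to compound 3 (0.75 log units; beyond the scatter) shows that the number also rises when the group at this place is a six-membered aromatic ring with 1 hetero atom, not only when a phenyl is added as in compound 1. Both groups have a net charge of +1 and 0 hydrogen-bond donors and acceptors, so these counts do not separate compound 2 from compound 3, and among these three compounds the group with no ring gives the lowest number, with no compound going against that. The step of a 1.8-fold lower number from compound 1 to compound 3 (0.25 log units; within the scatter) lies within the scatter, so the two ring-bearing groups cannot be told apart here, although they differ in heavy atoms, and nothing measured here accounts for any of these differences. Still open, on these data alone, is whether the ring itself or the larger count of heavy atoms goes with the higher number. A triethylammonium group, which has no ring, and a saturated piperidinium ring would help to separate those two readings.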